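Cyanopyridinyl Amide Built on the Series' Lowest Lipophilicity Point

The source may hold more compounds than are shown below. What is called first, only, known or untested is meant among the compounds shown, and "the series" means these compounds.

Of the compounds shown here, three sharing one core have been measured in a physicochemical assay for lipophilicity; on this read-out lower numbers stand for lower lipophilicity and higher numbers for higher lipophilicity. Compound 1 `COC[C@H](Oc1ncnc2c1cnn2-c1ccccc1Cl)C(=O)Nc1ccc(C)cn1` gives 3.4 in this assay. Compound 2 `Cc1cnc(NC(=O)[C@H](COC(C)C)Oc2ncnc3c2cnn3-c2ccccc2Cl)cn1` gives 2.1, and compound 3 `CC(C)OC[C@H](Oc1ncnc2c1cnn2-c1ncccc1Cl)C(=O)Nc1ccccn1` gives 2.5. Among these three, compound 2 stands lowest: the nearest number is that of compound 3, which lies higher by a margin beyond the usual scatter, and compound 1 lies higher still, also beyond the scatter. No two of the measured compounds differ in a single place, so none of these gaps can be tied to one structural change.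

Compound 4 `CC(C)OC[C@H](Oc1ncnc2c1cnn2-c1ccccc1Cl)C(=O)Nc1ccc(C#N)cn1` has not yet been measured in this assay. It is built from compound 2 by one change: 5-cyanopyridin-2-yl in place of 5-methylpyrazin-2-yl on an amide-type nitrogen. For the measured compounds named here, no measured pair in this set carries the same change, so its consequence for the distribution coefficient can only be estimated. For compound 4 the expected step is a number 0.30 log units higher from compound 2 to compound 4 (within the scatter), upward and about the size of the usual scatter, so it may not separate clearly from compound 2. The estimate for compound 4 in this assay is 2.4, within a range from 1.8 to 3.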

Compound 4, distribution coefficient: 3.5
Beside the measured number, compound 4's estimate is 1.10 log units below it, and the stated range ends below it.
By their numbers in this assay, from the lowest: compound 2; then compound 3; then compounds 1 and 4 (each within the scatter of the next).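

For the compounds shown here, on the amide-type nitrogen, whose other neighbour is the carbonyl carbon, the change from 5-methylpyrazin-2-yl to 5-cyanopyridin-2-yl gives the only single-place comparison in this set, and in this assay it reads a number 1.40 log units higher from compound 2 to compound 4 (beyond the scatter). The earlier compounds shown here offered no step at all, so none of their gaps could be tied to this position; now a change confined to this one group, with the same counts of hydrogen-bond donors and acceptors on both sides, is seen to move the number by a large margin. The two groups differ by one heavy atom, one ring hetero atom and the triple bond of the nitrile, and this single step does not divide its size among those differences.

On these data alone, what stays open is how the step splits between the ring and the nitrile, and whether a 5-cyanopyrazin-2-yl group or a 5-aminopyridin-2-yl group on the same amide-type nitrogen would fall nearer compound 2 or compound 4. Nothing at hand bears on why the step is this large.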